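Pyrazoline thioureas: chloro replaces nitro on the aryl arm

The source may report more compounds than this note shows. Statements on the series, on what has been measured and on what is new or still open speak of the compounds shown alone.

Compound 2 `O=[N+]([O-])c1ccc(C2=NN(C(=S)Nc3ccccc3)C(c3ccc4c(c3)OCCO4)C2)cc1` carries a 4-nitrophenyl group on the carbon with a double bond to nitrogen of the shared core. Within the data shown here, in a functional assay on HT-29 cells (Homo sapiens) for antiproliferative activity, read by MTT assay, with a stated time of 48 h (on this read-out lower numbers stand for stronger inhibition of growth and higher numbers for weaker inhibition of growth), compound 2 gives 153000 nM, the highest of the two numbers measured so far. Its nearest neighbour, compound 1 `S=C(Nc1ccccc1)N1N=C(c2ccccc2)CC1c1ccc2c(c1)OCCO2`, bears hydrogen at that position and gives 6630 nM in this assay. Among the measured compounds shown here, the one measured step that bears on the present question is a 23-fold higher number from compound 1 to compound 2 (1.36 log units; beyond the scatter), a large loss on putting the nitro group in.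

Compound 3 `S=C(Nc1ccccc1)N1N=C(c2cccc(Cl)c2)CC1c1ccc2c(c1)OCCO2` is the next member: 3-chlorophenyl in place of 4-nitrophenyl on a carbon with a double bond to nitrogen. This removes the nitro group whose introduction cost so much, and in its place puts a chlorine on the ring. For the measured compounds named here, no step in the set shows what a chlorine on this ring does; the one step available only says that the unsubstituted phenyl of compound 1 does far better than the 4-nitrophenyl of compound 2. The expectation is therefore a clear drop in this assay for compound 3 relative to compound 2, estimated as a 26-fold lower number from compound 2 to compound 3 (1.41 log units; beyond the scatter), bringing it back toward compound 1. The estimate for compound 3 in this assay is 6000 nM, within 1500 nM to 25000 nM.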

Compound 3, concentration for 50% growth inhibition: > 200000 nM
Compound 3 was reported as a limit; the forecaster's own chance of this, stated with the estimate: 5%; middle value at least 33-fold (1.52 log units) away from the limit.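

Compound 3 is reported as a limit, not as a number, in this assay: the limit of > 200000 nM in this assay, at which 1 of the 3 values shown sits. Among these compounds, the step on the phenyl ring, an at least 30-fold higher number from compound 1 to compound 3 (1.47 log units; beyond the scatter), shows that the large loss on this carbon with a double bond to nitrogen is not confined to the nitro group, since both the 3-chlorophenyl and the 4-nitrophenyl arms sit far from the unsubstituted phenyl of compound 1, the only member here that gives a value in the low range of the series. Replacing the 4-nitrophenyl arm with the 3-chlorophenyl arm, an at least 1.3-fold higher number from compound 2 to compound 3 (0.11 log units; that floor lies within the scatter), recovers no growth inhibition, although that floor lies within the scatter and the limit does not settle how far apart the two arms stand.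

This swap changes the group and its place on the ring together, so a 4-chlorophenyl or a 3-nitrophenyl arm would be needed to separate the two. From the compounds shown here alone, whether any group on this ring can match plain phenyl also stays open, for instance a methoxy group, an amine or a fluorine.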